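A Second Fluorine, This Time on the Benzyl Group

The compounds below may be only part of what the source reports. "The series", "measured", "known", "first", "only" and "open" are said of these compounds alone.

Compound 2 `Nc1nc(NCc2ccccc2)nc(-c2c(F)cccc2CO)n1` carries a fluorine that compound 1 `Nc1nc(NCc2ccccc2)nc(-c2ccccc2CO)n1` lacks, and in a functional assay on cells for positive allosteric modulation of G-protein coupled receptor 68 (Homo sapiens), read by a luciferase reporter and cAMP accumulation, with a stated time of 30 min, at pH 6.8 and pH 8.3, in the presence of a further agent that is not named here (on this read-out lower numbers stand for lower potency and higher numbers for higher potency (the scale is a negative logarithm)), compound 2 gives 3.69, the lowest of the three numbers measured. Compound 1 gives 4.35. Where compound 2 has fluorine, compound 3 `Nc1nc(NCc2ccccc2)nc(-c2c(Cl)cccc2CO)n1` has chlorine, and compound 3 gives 4.43. The steps are a number 0.66 log units lower from compound 1 to compound 2 (beyond the scatter) and a number 0.74 log units higher from compound 2 to compound 3 (beyond the scatter), while a number 0.08 log units higher from compound 1 to compound 3 (within the scatter).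

Compound 4 `Nc1nc(NCc2ccccc2F)nc(-c2c(F)cccc2CO)n1` differs from compound 2 by fluoro in place of hydrogen on an aromatic carbon; the benzyl group becomes a 2-fluorobenzyl. For the measured compounds named here, only the step from compound 1 to compound 2 involves adding fluorine, and that step was a modest loss, yet it was on a different ring, so it bears on the new change only loosely. Going by the values given here, no measured step concerns the benzyl group itself. Without a closer precedent, the most that can be drawn from these three compounds is that fluorine has not helped, and the expectation is a step of no more than modest size, most likely downward or flat.

Compound 4 is therefore expected to give about 3.6 in this assay, with a range from 3.1 to 4.2, meaning an estimated step of a number 0.09 log units lower from compound 2 to compound 4 (within the scatter).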

Compound 4, negative logarithm of the antagonist equilibrium constant: 4.22
Compound 4: the middle estimate sits 0.62 log units below what was measured; the measured number lies above the stated range.
By their numbers in this assay, from the lowest: compound 2; then compounds 4, 1 and 3 (each within the scatter of the next).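

The benzyl group is not a dead end for substitution: in this assay, fluoro in place of hydrogen on this ring, which turns benzyl into 2-fluorobenzyl, gives a number 0.53 log units higher from compound 2 to compound 4 (beyond the scatter). For the compounds shown here, the same swap on the other aromatic ring went the opposite way, with a number 0.66 log units lower from compound 1 to compound 2 (beyond the scatter), so across these two steps the effect of adding a fluorine depends on which ring receives it, and the earlier idea that fluorine simply does not help holds for only one of the two rings. This is a single step, measured with a fluorine already on the other ring, and nothing available here explains why the two swaps differ in direction.

The compounds shown leave open whether 2-fluorobenzyl would bring a similar rise on the core of compound 1, with no fluorine on the other ring, or on the core of compound 3, which carries chloro there. They also leave open what larger or different groups on the benzyl ring would do, such as chloro, methoxy, an amine or a carboxylic acid, and whether the other carbons of that ring respond as this one does.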